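Propyl to Isopropyl on Two Inactive Cores

The source may report more compounds than this note shows. Statements on the series, on what has been measured and on what is new or still open speak of the compounds shown alone.

Of the compounds shown here, three have been tested in a functional assay for inhibition, with Homo sapiens as the target; a lower number here means a stronger inhibitor, a higher number a weaker inhibitor. Compound 1 `CCCc1cnc(Nc2cc[nH]n2)n2c(CCC)nc(C)c12` and compound 2 `CCCc1nc(C)c2c(-c3ccccc3)nnc(SC)n12` differ in their cores, and that difference is not broken down here. Compound 3 `CSc1nnc(-c2ccccc2)c2c(C)nc(C(C)C)n12` arises from compound 2 by isopropyl in place of propyl on an aromatic carbon. In this assay compound 1 gives only a limit, > 48000 nM. Compound 2 likewise gives only a limit, > 48000 nM. Compound 3 also gives only a limit, > 48000 nM. Because all three sit at the limit of > 48000 nM in this assay, at which 3 of the 3 values shown sit, the step that the two limits leave unreadable from compound 2 to compound 3 cannot be read. Compound 4 `CCCc1nc(C)c2c(C(C)C)cnc(Nc3cc[nH]n3)n12` has not been measured; it arises from compound 1 by isopropyl in place of propyl on an aromatic carbon. This is the same kind of change as that from compound 2 to compound 3, not the same: there the place is on a five-membered aromatic ring with 2 nitrogen, between two ring nitrogen atoms, two ring bonds from the ring atom that bears a methyl group, whereas here it is on a six-membered aromatic ring with 2 nitrogen, ortho to a fused ring, two atoms from the ring nitrogen, meta to a fused ring, para to a (1H-pyrazol-3-yl)amino group. For compound 4 the expected step is a step that the limit leaves unreadable from compound 1 to compound 4. This rests on compound 1 giving only the limit > 48000 nM. It also rests on the unreadable step that the two limits leave unreadable from compound 2 to compound 3, which gives no sign of a gain. Compound 4 is estimated at 60000 nM, between 20000 nM and 200000 nM, most likely again reported only as a limit.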

Compound 4, half-maximal inhibitory concentration: > 48000 nM
Compound 4 gave a limit, no number; the forecaster's own chance of this, stated with the estimate: 85%; the middle value does not contradict the limit.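

No new step can be read from compound 1 to compound 4, because in this assay both give only a limit, not a number: the limit of > 48000 nM in this assay, at which 4 of the 4 values shown sit.

The compounds shown leave open how large the change from propyl to isopropyl really is on either core, and whether any compound with these cores gives a readable number in this assay.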